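This account rests on a few compounds, and the source may have more. Where it says the series, first, only, none or still open, it means among the compounds named here.

Measured so far in a functional assay on P388 cells (Mus musculus) for cytotoxicity; on this read-out lower numbers stand for stronger inhibition and higher numbers for weaker inhibition:
Compound 1, `CC(=O)O[C@]12C=CC(O)C[C@H]1OCC2`: in this assay compound 1 gives > 100 ug/mL, which is a limit of the assay and not a number.
Compound 2, `CCCCCC(=O)O[C@]12C=CC(O)C[C@H]1OCC2`: in this assay compound 2 gives 38.5 ug/mL.

Compound 2 thus holds the only number shown; the other value is a limit (the limit of > 100 ug/mL in this assay, at which 1 of the 2 values shown sits). Within the data shown here, the one measured step, an at least 2.5-fold lower number from compound 1 to compound 2 (0.41 log units; beyond the scatter), lengthens the ester chain, and the change now in view lengthens it further. Compound 3, `CCCCCCCC(=O)O[C@]12C=CC(O)C[C@H]1OCC2`, differs from compound 2 by ethyl in place of hydrogen on a saturated chain carbon, five bonds along the chain from a carbonyl carbon. Because the step of an at least 2.5-fold lower number from compound 1 to compound 2 (0.41 log units; beyond the scatter) was at least modest in this assay , a further lowering of the number is expected for compound 3, but a smaller one, as only ethyl enters here. The expected step is a 2.1-fold lower number from compound 2 to compound 3 (0.33 log units; beyond the scatter). For compound 3 the estimate is 18 ug/mL, with a range from 6 ug/mL to 60 ug/mL.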

Compound 3, half-maximal inhibitory concentration: 8.4 ug/mL
For compound 3 the middle estimate is 2.1-fold (0.33 log units) above the measured one; low and high end bracket the measured number.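

In this assay, the ester chain had not stopped responding at compound 2: ethyl in place of hydrogen, five bonds along the chain from a carbonyl carbon, still gives a 4.6-fold lower number from compound 2 to compound 3 (0.66 log units; beyond the scatter). Across the three compounds shown, the number falls with each lengthening and none goes against this, so that the two lengthenings together amount to an at least 11-fold lower number from compound 1 to compound 3 (1.07 log units; beyond the scatter). The size of that whole change rests on compound 1, whose value is a limit of the assay and not a number: the limit of > 100 ug/mL in this assay, at which 1 of the 3 values shown sits.

From the compounds shown here alone, what stays open is whether a longer chain would lower the number further or whether the trend would level off or turn back. Also open, going by these compounds, is how a branched chain, or an amine or a carboxylic acid at the chain end, would read at this position.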